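Hydroxylated side chain on an alkyne-linked amide core

The compounds below may be only part of what the source reports. "The series", "measured", "known", "first", "only" and "open" are said of these compounds alone.

Measured compounds:
compound 1 `C[C@@H](NC(=O)c1ccc(C#Cc2ccc(F)cn2)cn1)C(C)(C)O`: 64.6%
compound 2 `C[C@@H](NC(=O)c1nc(C#Cc2cccc(F)c2)cs1)C(C)(C)O`: 62.1%
compound 3 `CC(C)CNC(=O)c1ccc(C#Cc2cccc(F)c2)cn1`: 58.2%

In a functional assay on HEK293 cells for positive allosteric modulation of metabotropic glutamate receptor 5 (Rattus norvegicus), read by fluorescence and calcium flux (on this read-out higher numbers stand for larger maximal responses and lower numbers for smaller maximal responses), compound 3 gives 58.2%, and this number sits within the scatter of both compound 2 and compound 1, so the three are not distinguishable here. Compound 4 `CC(C)(O)CCNC(=O)c1ccc(C#Cc2cccc(F)c2)cn1` has not been measured in this assay. It differs from compound 3 in one place: 2-hydroxy-2-methylpropyl in place of isopropyl on a saturated chain carbon bound to an amide-type nitrogen. Going by the values given here, no pair of measured compounds differs in exactly this way, so no measured step guides the expectation; compound 1 with its hydroxyl-bearing chain does give 64.6% in this assay, within the scatter of compound 3. The step of a number 4.8 percentage points higher from compound 3 to compound 4 (within the scatter) is therefore expected to stay within the scatter. Compound 4 is estimated at 63%, between 50% and 76%.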

Compound 4, largest response reached (reported as efficacy), in percent of the reference or control that the assay uses: 61.9%
Estimate against measurement, compound 4: 1.1 percentage points above, within the range that was stated.
By their numbers in this assay, from the lowest: compounds 3, 4, 2 and 1 (each within the scatter of the next).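

In this assay, putting 2-hydroxy-2-methylpropyl in place of isopropyl on a saturated chain carbon bound to an amide-type nitrogen gives a number 3.7 percentage points higher from compound 3 to compound 4 (within the scatter) and so leaves the two compounds indistinguishable. Going by these compounds alone, this is the first comparison in which only this side chain differs, and it shows that this position accepts a hydroxyl-bearing chain on this core with a maximal response in the same range. Nothing measured here offers an explanation for this result. What the compounds shown leave open is whether an amine or a carboxylic acid on this chain, or a longer chain, would read the same way.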